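A few compounds are considered here, and "the series" means these few. Any claim that something is new, unique, unknown or untested is made for them only; others in the source may bear on it.

Compound 3 `O=C1CC(c2ccccc2Br)C(=O)N1CN1CCN(c2ccccc2)CC1` stands, in a functional assay on the whole organism (strain CF-1 albino) with Mus musculus as the target, with a stated time of 4 h (on this read-out higher numbers stand for an effect only at larger amounts of compound and lower numbers for an effect already at smaller amounts), at 100 mg/kg. Compound 2 `O=C1CC(c2ccccc2F)C(=O)N1CN1CCN(c2cccc(C(F)(F)F)c2)CC1` gives 100 mg/kg, so compound 3 is level with compound 2 at the digits shown, and the two together sit at the low end of the three numbers, within the scatter of each other. Compound 1 `O=C1CC(c2ccccc2F)C(=O)N1CN1CCN(c2ccccc2)CC1` gives 300 mg/kg; the step of a 3.0-fold lower number from compound 1 to compound 3 (0.48 log units; beyond the scatter) lies beyond the scatter, as does a 3.0-fold lower number from compound 1 to compound 2 (0.48 log units; beyond the scatter).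

Compound 4 `O=C1CC(c2ccccc2Br)C(=O)N1CN1CCN(c2cccc(Cl)c2)CC1` differs from compound 3 by chloro in place of hydrogen on an aromatic carbon, on an aromatic carbon of a six-membered aromatic ring of carbon only, meta to a large group. For the measured compounds named here, the one measured step that bears on this change is a 3.0-fold lower number from compound 1 to compound 2 (0.48 log units; beyond the scatter), where a substituent takes the spot of a hydrogen atom; it was modest and toward a lower number. A step of the same direction and of similar or smaller size is therefore expected for compound 4 in this assay, a 2.0-fold lower number from compound 3 to compound 4 (0.30 log units; within the scatter). Compound 4 is estimated at 50 mg/kg, with a range from 30 mg/kg to 100 mg/kg.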

Compound 4, minimum effective dose: 100 mg/kg
Compound 4: the middle estimate sits 2.0-fold (0.30 log units) below what was measured; the measured number falls inside the stated range.
By their numbers in this assay, from the lowest: compounds 2, 3 and 4 (each within the scatter of the next); then compound 1.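

Chloro in place of hydrogen, meta to a large group, gives no change at the digits printed from compound 3 to compound 4 (within the scatter) in the series carrying bromo, so a substituent at this position does not lower the number in every case shown. The earlier 3.0-fold lower number from compound 1 to compound 2 (0.48 log units; beyond the scatter) came with trifluoromethyl in the series carrying fluoro, and compound 4 goes against reading that step as general. The two steps differ in both the entering group and the halogen elsewhere in the molecule, and nothing available explains the result.

Open, from the compounds shown here alone, is whether the difference between the two steps follows the entering group or the halogen, which trifluoromethyl with bromo or chloro with fluoro would address. Also open, going by these compounds, is how an amine, a carboxylic acid or a methoxy group at this position would read out.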